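This account rests on a few compounds, and the source may have more. Where it says the series, first, only, none or still open, it means among the compounds named here.

Measured in a functional assay on SGC-7901 cells (Homo sapiens) for antiproliferative activity, read by MTT assay, with a stated time of 72 h; a higher number here means a weaker inhibitor, a lower number a stronger inhibitor:
- compound 1 `COc1ccccc1-c1ccc2ncn(-c3cc(OC)c(OC)c(OC)c3)c2c1`: 5050 nM
- compound 2 `COc1cc(-n2cnc3ccc(-c4ccccc4Cl)cc32)cc(OC)c1OC`: > 10000 nM, a limit of the assay and not a number
- compound 3 `COc1cc(-n2cnc3ccc(-c4cccc([N+](=O)[O-])c4)cc32)cc(OC)c1OC`: 380 nM

Compound 3 is the strongest of the three, with both of its neighbours clearly behind it. The next structure, compound 4 `COc1ccc(-c2ccc3ncn(-c4cc(OC)c(OC)c(OC)c4)c3c2)cc1`, has 4-methoxyphenyl in place of 3-nitrophenyl on an aromatic carbon.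

Two measured steps changed this same group, and both were large: a 13-fold lower number from compound 1 to compound 3 (1.12 log units; beyond the scatter), and an at least 26-fold lower number from compound 2 to compound 3 (1.42 log units; beyond the scatter). The step of an at least 1.9-fold higher number from compound 1 to compound 2 (0.29 log units; that floor lies within the scatter) is a smaller guide, since it rests on a limit. Compound 4 gives up the 3-nitrophenyl group that only compound 3 carries, and it holds a methoxyphenyl group, as compound 1 does with its 2-methoxyphenyl. The methoxy group sits elsewhere on that ring, however, so compound 1 at 5050 nM is only a loose guide.

A rise in the number is therefore expected, with an estimated 3.9-fold higher number from compound 3 to compound 4 (0.60 log units; beyond the scatter) in this assay. For compound 4 the expected value is 1500 nM, with an estimated range from 250 nM to 8000 nM.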

Compound 4, half-maximal inhibitory concentration: 82 nM
Estimate against measurement, compound 4: 18-fold (1.26 log units) above; the measured number lies below the stated range.
By their numbers in this assay, from the lowest: compound 4; then compound 3; then compound 1. At a limit, above all of these: compound 2.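

In this assay, the same methoxy group on the same ring gives a very different result with 4-methoxyphenyl in place of 2-methoxyphenyl, a change that amounts to a 62-fold lower number from compound 1 to compound 4 (1.79 log units; beyond the scatter). The 3-nitrophenyl group of compound 3 is also not needed to reach the lowest number here, as a 4.6-fold lower number from compound 3 to compound 4 (0.67 log units; beyond the scatter) shows. Against compound 2 the change is an at least 120-fold lower number from compound 2 to compound 4 (2.08 log units; beyond the scatter), but compound 2 stands at a limit of the assay and not a number, so this step is only a floor: the limit of > 10000 nM in this assay, at which 1 of the 4 values shown sits.

The compounds shown leave open whether the methoxy group itself matters, or whether other groups in its place on this ring would do as well. An amine, a hydroxyl group or a longer chain such as ethoxy there would help to settle this.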